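A few compounds are considered here, and "the series" means these few. Any claim that something is new, unique, unknown or untested is made for them only; others in the source may bear on it.

Compound 1 `CCCCCCCCS(=O)(=O)Nc1cc(-c2ccc(Cl)cc2)ccc1C(=O)O` and compound 2 `CCCCCCCCS(=O)(=O)Nc1ccc(-c2ccc(Cl)cc2)cc1C(=O)O` share a core and differ only in where the octylsulfonamide and the chlorophenyl sit. In an assay on mitochondria (strain BALB/c) for inhibition of glycerol-3-phosphate acyltransferase 1, mitochondrial (Mus musculus), read by scintillation counting, with a stated time of 10 min (on this read-out lower numbers stand for stronger inhibition and higher numbers for weaker inhibition), compound 1 gives 18100 nM, and compound 2 gives 9200 nM; the two numbers lie within the usual scatter of each other, so neither can be set above the other. Compound 3 `CCCCCCCCS(=O)(=O)Nc1ccc(-c2ccc(O)cc2)cc1C(=O)O` differs from compound 2 by one change: hydroxy in place of chloro on an aromatic carbon. Going by the values given here, no measured pair shows this change, so the step from compound 2 to compound 3 is expected to be modest, toward a higher number, as a 2.2-fold higher number from compound 2 to compound 3 (0.34 log units; beyond the scatter). Compound 3 is therefore estimated at 20000 nM, with a range of 6000 nM to 60000 nM.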

Compound 3, half-maximal inhibitory concentration: 47300 nM
The estimate for compound 3 lay 2.4-fold (0.37 log units) below the measured number, and the stated range covers the measured number.
By their numbers in this assay, from the lowest: compounds 2 and 1 (each within the scatter of the next); then compound 3.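

Replacing chloro with hydroxy on the aromatic carbon para to a large group gives a 5.1-fold higher number from compound 2 to compound 3 (0.71 log units; beyond the scatter) in this assay. This is the first step among these compounds that lies beyond the scatter, so the group at this place matters, whereas compounds 1 and 2 could not be set apart. Nothing available here accounts for the size or direction of this step. Open, as far as these compounds go, is how a methoxy or an amine on the same carbon would read, and whether hydroxy in place of chloro gives a similar step on the arrangement of compound 1.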